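Swapping trifluoromethyl for methyl on the aryl ether oxygen

The source may hold more compounds than are shown below. What is called first, only, known or untested is meant among the compounds shown, and "the series" means these compounds.

Measured so far in a functional assay on U-937 cells (Homo sapiens) for antiproliferative activity, read by MTT assay; on this read-out lower numbers stand for stronger inhibition and higher numbers for weaker inhibition:
compound 1 `C#CCN(c1ncccn1)c1nc2ccccc2s1` gives 15700 nM;
compound 2 `FC(F)(F)Sc1ccc(-c2cc(CN(c3ncccn3)c3nc4ccccc4s3)on2)cc1` gives 19400 nM;
compound 3 `FC(F)(F)Oc1ccc(-c2cc(CN(c3ncccn3)c3nc4ccccc4s3)on2)cc1` gives 13500 nM.

Compound 3 sits at the low end of these three numbers, but its gaps to compound 1 and to compound 2 are both within the scatter, so none of the three can be called stronger in this assay. For the measured compounds named here, the only step measured between neighbours is a 1.4-fold lower number from compound 2 to compound 3 (0.16 log units; within the scatter), and it is itself within the scatter.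

Compound 4 `COc1ccc(-c2cc(CN(c3ncccn3)c3nc4ccccc4s3)on2)cc1` differs from compound 3 by methyl in place of trifluoromethyl on an oxygen on an aromatic ring. Going by the values given here, no measured step touches this exact change; the one step available shows that swapping a group at this position changed little. For compound 4 the expected step is therefore a 1.0-fold higher number from compound 3 to compound 4 (0.02 log units; within the scatter). Compound 4 is estimated at 14000 nM, within a range from 6000 nM to 35000 nM.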

Compound 4, half-maximal inhibitory concentration: 13900 nM
Compound 4: the middle estimate sits 1.0-fold (0.00 log units) above what was measured; the measured number falls inside the stated range.
By their numbers in this assay, from the lowest: compounds 3, 4, 1 and 2 (each within the scatter of the next).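

In this assay, methyl in place of trifluoromethyl on the aromatic oxygen gives a 1.0-fold higher number from compound 3 to compound 4 (0.01 log units; within the scatter) and methoxy in place of (trifluoromethyl)sulfanyl gives a 1.4-fold lower number from compound 2 to compound 4 (0.14 log units; within the scatter) as its second step, so both are within the scatter. Across compounds 2, 3 and 4, three quite different groups at this spot therefore leave no readable difference in this assay, and removing all the fluorine from the ether changes nothing that can be read. No measurement here offers an explanation for this flat result.

Going by these compounds, it remains open whether an amine or a carboxylic acid at this spot, or a longer chain on the oxygen, would shift the number beyond the scatter. On these data alone, it also remains open whether changes to the shared core would do so.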